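This account rests on a few compounds, and the source may have more. Where it says the series, first, only, none or still open, it means among the compounds named here.

Measured so far in a functional assay on MDA-MB-231 cells (Homo sapiens) for inhibition, read by MTT assay, with a stated time of 72 h; on this read-out lower numbers stand for stronger inhibition and higher numbers for weaker inhibition. Compound 1 `C=CC(=O)Nc1cccc(NC(=O)CSc2nc(Nc3ccccc3F)c3ccccc3n2)c1` gives 18700 nM. Compound 2 `C=CC(=O)Nc1cccc(NC(=O)CSc2nc(Nc3cccc(Cl)c3)c3ccccc3n2)c1` gives 16300 nM. Compound 3 `C=CC(=O)Nc1cccc(NC(=O)CSc2nc(Nc3cccc([N+](=O)[O-])c3)c3ccccc3n2)c1` reports only a limit of this assay, > 50000 nM.

Compound 3 therefore stands at the limit of this assay (the limit of > 50000 nM in this assay, at which 1 of the 3 values shown sits), with no number of its own. Compound 4 `C=CC(=O)Nc1cccc(NC(=O)CSc2nc(Nc3ccc(F)cc3)c3ccccc3n2)c1` differs from compound 3 by 4-fluorophenyl in place of 3-nitrophenyl on a nitrogen on an aromatic ring. Among the compounds with values here, the steps that bear on this change are an at least 2.6-fold higher number from compound 1 to compound 3 (0.42 log units; beyond the scatter) and an at least 3.0-fold higher number from compound 2 to compound 3 (0.48 log units; beyond the scatter), both beyond the scatter, while a 1.1-fold lower number from compound 1 to compound 2 (0.06 log units; within the scatter) keeps the two halophenyl compounds together. Returning to a fluorophenyl is therefore expected to give a clearly lower number, the step of an at least 2.7-fold lower number from compound 3 to compound 4 (0.44 log units; beyond the scatter) being the expectation. Compound 4 is estimated at 18000 nM, in a range from 8000 nM to 45000 nM.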

Compound 4, half-maximal inhibitory concentration: 9490 nM
For compound 4 the middle estimate is 1.9-fold (0.28 log units) above the measured one; the range from low to high includes it.
By their numbers in this assay, from the lowest: compounds 4, 2 and 1 (each within the scatter of the next). At a limit, above all of these: compound 3.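

Among the groups on this nitrogen, 4-fluorophenyl sits with the other halophenyl compounds, an at least 5.2-fold lower number from compound 3 to compound 4 (0.72 log units; beyond the scatter), so the separation of the 3-nitrophenyl compound now holds against all three halophenyl compounds. Neither the halogen nor its place on the ring separates those compounds: a 1.7-fold lower number from compound 2 to compound 4 (0.23 log units; within the scatter) and a 2.0-fold lower number from compound 1 to compound 4 (0.29 log units; within the scatter) both stay within the scatter. Compound 3 still stands only at a limit of the assay: the limit of > 50000 nM in this assay, at which 1 of the 4 values shown sits.

On these data alone, it remains open how a 4-nitrophenyl, 3-aminophenyl or 4-methoxyphenyl group on this nitrogen would read. Also open, as far as these compounds go, is whether the nitro group itself or its place on the ring sets compound 3 apart.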